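A few compounds are considered here, and "the series" means these few. Any claim that something is new, unique, unknown or untested is made for them only; others in the source may bear on it.

Measured so far:
- compound 1 `O=C(CSCc1nc2cc([N+](=O)[O-])ccc2[nH]1)c1ccccc1`: 16100 nM
- compound 2 `N#Cc1sc(Nc2ccccc2)nc1NC(=O)CSCc1nc2cc([N+](=O)[O-])ccc2[nH]1`: 9480 nM

Both numbers come from a functional assay on HepG2 cells (Homo sapiens) for cytotoxicity, read by MTT assay, with a stated time of 48 h; on this read-out lower numbers stand for stronger inhibition and higher numbers for weaker inhibition. With only these two compounds on record, compound 1 and compound 2 lie within the usual scatter of each other, so neither can be set apart from the other. Among the compounds with values here, compound 1 therefore stands level with the only other measured compound, and no pair measured so far differs in just one place.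

The next compound to be tested is compound 3 `NNC(=O)CSCc1nc2cc([N+](=O)[O-])ccc2[nH]1`, which keeps the core of compound 1 and has aminoamino in place of phenyl on a carbonyl carbon. Within the data shown here, no measured step shows what this exchange does. Among the measured compounds shown here, the only indirect guide is compound 2, which has a different group on the carbonyl carbon and gives 9480 nM, within the scatter of compound 1. On that slender basis, no step beyond the scatter is expected in this assay, in either direction. The estimated step is a 1.1-fold lower number from compound 1 to compound 3 (0.03 log units; within the scatter). For compound 3 the expected value is 15000 nM, with an estimated range of 6000 nM to 40000 nM.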

Compound 3, half-maximal inhibitory concentration: 18600 nM
Compound 3: middle estimate off by 1.2-fold (0.09 log units), on the low side; low and high end bracket the measured number.
By their numbers in this assay, from the lowest: compounds 2, 1 and 3 (each within the scatter of the next).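

In this assay, within the data shown here, the exchange of phenyl for aminoamino on a carbonyl carbon whose other neighbour is a saturated chain carbon gives a 1.2-fold higher number from compound 1 to compound 3 (0.06 log units; within the scatter), and this is the first single-place step available at this position. Phenyl, with 6 heavy atoms, one six-membered aromatic ring and 0 hydrogen-bond donors, gives way to aminoamino, with 2 heavy atoms, no ring and 2 hydrogen-bond donors, yet the two compounds cannot be told apart in this read-out, so in this pair a large change in the group on the carbonyl carbon leaves the number within the scatter. Nothing available explains why these two groups read alike.

This single pair leaves open whether any group on this carbonyl carbon can move the number beyond the scatter, and it cannot be taken as a pattern for the position as a whole. A methyl group, a hydroxyl group, a simple amine or a longer chain ending in a carboxylic acid at the same place could each test this, and the compounds shown give no reading for any of them.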